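From morpholin-4-yl to benzylamino on a carbonyl carbon

This account rests on a few compounds, and the source may have more. Where it says the series, first, only, none or still open, it means among the compounds named here.

Among the measured compounds shown here, in a functional assay on HL-60 cells (Homo sapiens) for antiproliferative activity, read by MTT assay, with a stated time of 24 h (on this read-out higher numbers stand for weaker inhibition and lower numbers for stronger inhibition), compound 2 `CCCCc1oc2ccccc2c1C(=O)c1ccc(OCCCC(=O)N2CCOCC2)cc1` gives 34100 nM, the only actual number so far. Compound 1 `CCCCNC(=O)CCCOc1ccc(C(=O)c2c(CCCC)oc3ccccc23)cc1` gives > 50000 nM, which is a limit of the assay and not a number. Compound 3 `CCCCc1oc2ccccc2c1C(=O)c1ccc(OCCCC(=O)NCc2ccccc2)cc1` differs from compound 2 in one place (benzylamino in place of morpholin-4-yl on a carbonyl carbon), with benzylamino in place of morpholin-4-yl on a carbonyl carbon. For the measured compounds named here, the one measured step at this place, an at least 1.4-fold lower number from compound 1 to compound 2 (0.16 log units; that floor lies within the scatter), put morpholin-4-yl in place of butylamino. Going by the values given here, with only that small step to go on, no change beyond the scatter is expected in this assay, and the expected step is a 1.0-fold higher number from compound 2 to compound 3 (0.01 log units; within the scatter). For compound 3 the estimated value is 35000 nM, with an expected range from 12000 nM to 50000 nM.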

Compound 3, half-maximal inhibitory concentration: 28900 nM
Estimate against measurement, compound 3: 1.2-fold (0.08 log units) above, within the range that was stated.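

The step of a 1.2-fold lower number from compound 2 to compound 3 (0.07 log units; within the scatter) shows that in this assay benzylamino and morpholin-4-yl on this carbonyl carbon cannot be told apart. The step of an at least 1.7-fold lower number from compound 1 to compound 3 (0.23 log units; that floor lies within the scatter) for phenyl in place of propyl is only a floor. Compound 1 gives a limit and not a number, so the true size of that step stays unknown because of this limit: the limit of > 50000 nM in this assay, at which 1 of the 3 values shown sits.

Going by these compounds, whether a piperazine or a free carboxylic acid in this place would move the number beyond the scatter stays open. Also open, on these data alone, is what a change elsewhere on the shared core would do.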